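The source may report more compounds than this note shows. Statements on the series, on what has been measured and on what is new or still open speak of the compounds shown alone.

Measured so far:
Compound 1 `Cc1c(C(=O)Nc2ccc(Oc3ncnc4[nH]cc(-c5ccccc5)c34)c(F)c2)c(=O)c2cc(C(F)(F)F)ccc2n1C` gives 150 nM in an assay on isolated protein for inhibition of tyrosine-protein kinase receptor UFO (Homo sapiens), read by FRET and Z'-LYTE, with a stated time of 1.5 h; a higher number here means a weaker inhibitor, a lower number a stronger inhibitor.
Compound 2 `CCn1c(C)c(C(=O)Nc2ccc(Oc3ncnc4[nH]cc(-c5ccccc5)c34)c(F)c2)c(=O)c2cc(C)ccc21` gives 150 nM in this assay.
Compound 3 `CCc1ccc2c(c1)c(=O)c(C(=O)Nc1ccc(Oc3ccnc(N)c3Cl)c(F)c1)c(C)n2C` gives 72 nM in this assay.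

Compound 1 stands level with compound 2 at the digits given, the two of them together the highest numbers of the three, while compound 3 shows a lower number that lies beyond the usual scatter. The unmeasured compound 4 `Cc1c(C(=O)Nc2ccc(Oc3ncnc4[nH]cc(-c5ccccc5)c34)c(F)c2)c(=O)c2cc(C3CCCC3)ccc2n1C` differs from compound 1 in one place: cyclopentyl in place of trifluoromethyl on an aromatic carbon. Compound 2 carries methyl at that same place and gives 150 nM, which matches compound 1 and suggests that the group here moves the number little. The expected step in this assay is therefore no change at the digits printed from compound 1 to compound 4 (within the scatter), none beyond the scatter in either direction. Compound 4 is estimated at 150 nM, with a range from 60 nM to 400 nM.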

Compound 4, half-maximal inhibitory concentration: 200 nM
The estimate for compound 4 lay 1.3-fold (0.12 log units) below the measured number; the range from low to high includes it.
By their numbers in this assay, from the lowest: compound 3; then compounds 1, 2 and 4 (each within the scatter of the next).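

In this assay, among these compounds, cyclopentyl in place of trifluoromethyl on this aromatic carbon gives a 1.3-fold higher number from compound 1 to compound 4 (0.12 log units; within the scatter), the first comparison at this position that changes only the one group. The position therefore accepts a five-membered non-aromatic ring of carbon only in place of trifluoromethyl without a step beyond the scatter. No measurement here bears on the reason for this.

As far as these compounds go, whether the same holds for a group carrying hydrogen-bond donors or acceptors, such as an amine or a carboxylic acid, stays open. So does the outcome for a longer chain or a phenyl ring at this place.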